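The compounds below may be only part of what the source reports. "The series", "measured", "known", "first", "only" and "open" are said of these compounds alone.

Measured compounds:
Compound 1, `COC(CCn1cnc2c(NCc3ccc(C(=O)Nc4ccccc4N)cc3)nc(Cl)nc21)OC`: 11.9%
Compound 2, `CC(C)n1cnc2c(Nc3ccccc3)nc(NCOCc3ccc(C(=O)Nc4ccccc4N)cc3)nc21`: 18.8%
Compound 3, `CCCCn1cnc2c(Nc3cccc(Cl)c3)nc(NCOCc3ccc(/C=C/C(=O)Nc4ccccc4N)cc3)nc21`: 10.9%

In a functional assay on HCT-116 cells (Homo sapiens) for antiproliferative activity, read by CCK-8 assay, with a stated time of 72 h, tested at 8 uM (a higher number here means a stronger effect of the compound at the concentration tested, a lower number a weaker effect), the three measured compounds all give small readings. Compound 1 gives 11.9% in this assay, and that number lies within the usual scatter of the number for compound 3 and also within the usual scatter of the number for compound 2, so no order among the three can be read from these values. The shared core of compound 1 carries a 3,3-dimethoxypropyl group on an aromatic nitrogen, and compound 4, `CCC(C)n1cnc2c(NCc3ccc(C(=O)Nc4ccccc4N)cc3)nc(Cl)nc21`, differs from it in exactly one place: sec-butyl in place of 3,3-dimethoxypropyl on an aromatic nitrogen. No measured pair in this set shows the effect of such a swap at that position, so the expectation for this assay rests only on the small readings of the three compounds shown. Because compound 1 gives 11.9% and the other two measured compounds give numbers within the scatter of it, the step from compound 1 to compound 4 is expected to be a number 2.1 percentage points higher from compound 1 to compound 4 (within the scatter), which is no change beyond the scatter. Compound 4 is therefore estimated to give 14% in this assay, with a range from 2% to 30%.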

Compound 4, a percentage reported as inhibition, at one concentration (the size of the read-out at that concentration, not a potency): 75.1%
Compound 4: middle estimate off by 61.1 percentage points, on the low side; measured number above the stated range.
By their numbers in this assay, from the lowest: compounds 3, 1 and 2 (each within the scatter of the next); then compound 4.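

In this assay, among these compounds, sec-butyl in place of 3,3-dimethoxypropyl on an aromatic nitrogen gives a number 63.2 percentage points higher from compound 1 to compound 4 (beyond the scatter), the first step in this set that lies outside the scatter. Among the compounds shown here, the earlier compounds gave only small readings with no order among them, and no pair differed in one place, so this change is the first to show that this position alone can move the read-out. The change swaps a chain carrying two hydrogen-bond acceptors for a smaller all-carbon group, but nothing shown here tells which of these differences counts, and no measurement bears on the cause.

The compounds shown leave open whether a cyclopentyl ring, an amine or a carboxylic acid at this position would keep or lose the reading. They also leave open whether the step holds with other groups elsewhere on the shared core.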